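Chain-shortened iodoacetamide adenosine triphosphates against hexokinase-2

The source may report more compounds than this note shows. Statements on the series, on what has been measured and on what is new or still open speak of the compounds shown alone.

Compound 1 `O=C(CI)NCCCCCCCCNc1ncnc2c1ncn2[C@@H]1O[C@H](COP(=O)(O)OP(=O)(O)OP(=O)(O)O)[C@@H](O)[C@H]1O` gives 41% in an assay on isolated protein for inhibition of hexokinase-2 (Rattus norvegicus), with a stated time of 6 h, tested at 10 mM; on this read-out higher numbers stand for more inhibition at the one concentration tested (going by the name of the read-out) and lower numbers for less inhibition. Compound 2 `O=C(CI)NCCCCNc1ncnc2c1ncn2[C@@H]1O[C@H](COP(=O)(O)OP(=O)(O)OP(=O)(O)O)[C@@H](O)[C@H]1O` carries ((iodomethyl)carbonyl)amino in place of 4-(((iodomethyl)carbonyl)amino)butyl on a saturated chain carbon, four bonds along the chain from a nitrogen on an aromatic ring; in this assay compound 2 gives 0%, a step of a number 41 percentage points lower from compound 1 to compound 2 (beyond the scatter). Compound 3 `Nc1ncnc2c1nc(NCCCCCCNC(=O)CI)n2[C@@H]1O[C@H](COP(=O)(O)OP(=O)(O)OP(=O)(O)O)[C@@H](O)[C@H]1O` has a core whose difference from compound 1 is not broken down here; in this assay compound 3 gives 0%, level with compound 2. Compound 4 `Nc1ncnc2c1nc(NCCNC(=O)CI)n2[C@@H]1O[C@H](COP(=O)(O)OP(=O)(O)OP(=O)(O)O)[C@@H](O)[C@H]1O` carries ((iodomethyl)carbonyl)amino in place of 4-(((iodomethyl)carbonyl)amino)butyl on a saturated chain carbon, two bonds along the chain from a nitrogen on an aromatic ring, the same kind of change as from compound 1 to compound 2, though the place differs: two bonds along the chain from the ring nitrogen rather than four. Since compound 3 already reads 0%, little room remains downward, and the chain-shortening step is expected to read a number 2 percentage points higher from compound 3 to compound 4 (within the scatter). Compound 4 is therefore estimated at 2%, within 0% to 12%.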

Compound 4, a percentage reported as inhibition, at one concentration (the size of the read-out at that concentration, not a potency): 0%
Beside the measured number, compound 4's estimate is 2 percentage points above it; low and high end bracket the measured number.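

In this assay, the chain-shortening change gives no change at the digits printed from compound 3 to compound 4 (within the scatter), so it does not carry from one core to the other at the size seen earlier: the same change on two cores in this assay, a number 41 percentage points lower (beyond the scatter) from compound 1 to compound 2 and no change at the digits printed (within the scatter) from compound 3 to compound 4, 41 percentage points apart, beyond the scatter of two such steps. Compound 3 already reads 0%, leaving no room downward, so this flat step cannot show whether the change would lower a core that starts higher. The comparison also does not separate the effect of the core from that of the place of the change, two rather than four bonds along the chain from the ring nitrogen.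

Open, on these data alone, is whether a longer chain on the core of compound 3 would raise the reading. Also open, as far as these compounds go, is how a chloroacetyl group would read in place of the ((iodomethyl)carbonyl) group on either core.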